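The compounds below may be only part of what the source reports. "The series", "measured", "known", "first", "only" and "open" are said of these compounds alone.

Compound 3, `CCOC(=O)C1=Cc2ccccc2OC1(OCc1cn(-c2ccc(F)c(Cl)c2)nn1)C(F)(F)F`, is the only one of the three measured compounds to give a number in a functional assay on MCF7 cells (Homo sapiens) for inhibition, read by MTT assay, with a stated time of 24 h (on this read-out lower numbers stand for stronger inhibition and higher numbers for weaker inhibition), where compound 3 gives 25300 nM. Compound 1, `CCOC(=O)C1=Cc2ccccc2OC1(OCc1cn(CC(=O)Nc2ccc(C)cc2)nn1)C(F)(F)F`, gives only a limit of the assay in this assay, namely > 150000 nM. Compound 2, `CCCCCCCCn1cc(COC2(C(F)(F)F)Oc3ccccc3C=C2C(=O)OCC)nn1`, likewise gives only a limit, > 150000 nM. The step that the two limits leave unreadable from compound 1 to compound 2 therefore cannot be read. The two steps that reach compound 3 are both readable as limits: an at least 5.9-fold lower number from compound 1 to compound 3 (0.77 log units; beyond the scatter) and an at least 5.9-fold lower number from compound 2 to compound 3 (0.77 log units; beyond the scatter), each replacing a chain on the aromatic nitrogen with an aryl ring; a summary is given by the limit of > 150000 nM in this assay, at which 2 of the 3 values shown sit.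

Compound 4, `CCOC(=O)C1=Cc2ccccc2OC1(OCc1cn(-c2cccc(C(F)(F)F)c2)nn1)C(F)(F)F`, keeps the aryl ring on that nitrogen and changes only its substituents: 3-(trifluoromethyl)phenyl in place of 3-chloro-4-fluorophenyl on an aromatic nitrogen. Going by the values given here, no measured step exchanges one aryl for another here; both readable steps concern aryl in place of a chain, so they set a frame for compound 4 but do not fix its size. An aryl-to-aryl swap of this kind is expected to give a step in this assay no larger than the scatter, a 1.2-fold higher number from compound 3 to compound 4 (0.07 log units; within the scatter), in either direction. Compound 4 is therefore expected to give about 30000 nM in this assay, within a range from 10000 nM to 100000 nM.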

Compound 4, half-maximal inhibitory concentration: > 150000 nM
Compound 4: a limit, no number; the forecaster's own chance of this, stated with the estimate: 20%; middle value at least 5.0-fold (0.69 log units) from the limit.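

Both earlier readable steps set an aryl ring in place of a chain, so they could not separate the ring itself from what it carries; the exchange of one aryl ring for another now does, giving an at least 5.9-fold higher number from compound 3 to compound 4 (0.77 log units; beyond the scatter) in this assay. On this aromatic nitrogen, then, an aryl ring alone does not secure a number in this read-out, for the leaving and the entering group each hold one six-membered aromatic ring of carbon only and no hydrogen-bond donors or acceptors, and they part in their substituents. The steps from compound 1 and from compound 2 to compound 4 join two limits and cannot be read, which leaves compound 3 alone with a number: the limit of > 150000 nM in this assay, at which 3 of the 4 values shown sit.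

The compounds shown leave open whether the chlorine, the fluorine or the two together in 3-chloro-4-fluorophenyl go with the number of compound 3, which a plain phenyl ring or a ring with one chlorine would begin to settle. Also open, from the compounds shown here alone, is whether a methoxy group on that ring, or a carboxylic acid in place of the ethyl ester on the shared core, would change the read-out.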